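Swapping the benzyl arm for a trifluoromethylphenyl ring

The source may report more compounds than this note shows. Statements on the series, on what has been measured and on what is new or still open speak of the compounds shown alone.

Measured so far:
- compound 1, `Cc1ccccc1-c1nn(Cc2ccc(F)cc2)cc1CNCCN1CCN(C)CC1`: > 20000 nM
- compound 2, `CN1CCN(CCNCc2cn(-c3ccc(C(F)(F)F)cc3)nc2-c2ccc(C(F)(F)F)cc2)CC1`: 1500 nM
- compound 3, `COC(=O)c1ccc(-c2nn(-c3ccc(F)cc3F)cc2CNCCN2CCN(C)CC2)cc1`: > 20000 nM

In an ADME assay on Huh-7 cells (Homo sapiens) for cytotoxicity (a higher number here means that more compound is tolerated, a lower number that less compound is tolerated), compound 1 reaches only the limit of the assay, > 20000 nM, so its true tolerated concentration is not known as a number. The same holds for compound 3, which in this assay also sits at the limit, > 20000 nM. Among the measured compounds shown here, compound 2, which carries two trifluoromethyl-bearing groups, is the one compound of the three with a number in this assay, 1500 nM. Thus the limit of > 20000 nM in this assay, at which 2 of the 3 values shown sit, describes where compound 1 stands: among the better-tolerated members, with no value to set it apart from compound 3.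

Compound 4, `Cc1ccccc1-c1nn(-c2cccc(C(F)(F)F)c2)cc1CNCCN1CCN(C)CC1`, differs from compound 1 in one place: 3-(trifluoromethyl)phenyl in place of 4-fluorobenzyl on an aromatic nitrogen. For the measured compounds named here, no pair of measured compounds shows this change alone, so its effect is unknown; the only hint is compound 2, where trifluoromethyl groups go with a measured number.

Compound 4 is therefore expected to give about 9000 nM, with a range from 2500 nM to 20000 nM. The expected step of an at least 2.2-fold lower number from compound 1 to compound 4 (0.34 log units; beyond the scatter) points toward less tolerance, but since compound 1 is only a limit, the step could also be no more than scatter.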

Compound 4, half-maximal cytotoxic concentration: 18000 nM
Compound 4: the middle estimate sits 2.0-fold (0.30 log units) below what was measured, within the range that was stated.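

In this assay, among the compounds shown here, replacing 4-fluorobenzyl with 3-(trifluoromethyl)phenyl on the aromatic nitrogen gives an at least 1.1-fold lower number from compound 1 to compound 4 (0.04 log units; that floor lies within the scatter), the first direct reading of this change. The floor of that step does not show that the change costs any tolerance. This position can carry the trifluoromethyl-bearing ring, and compound 4 gives 18000 nM. On these data alone, the full size of the step stays unknown because compound 1 sits at a limit of the assay: the limit of > 20000 nM in this assay, at which 2 of the 4 values shown sit.

The change alters both the fluorine-bearing substituent and the carbon link between the ring and the nitrogen, so the compounds shown cannot separate these two parts. A plain phenyl or a 3-(trifluoromethyl)benzyl group on that nitrogen would be needed to tell them apart, and neither is among these compounds.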